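Three indole oxadiazolines at the limit, a bromo analogue awaited

A few compounds are considered here, and "the series" means these few. Any claim that something is new, unique, unknown or untested is made for them only; others in the source may bear on it.

Compound 1 `O=C(/C=C\c1ccccc1)N1N=C(c2ccncc2)OC1c1c[nH]c2ccccc12` — in an ADME assay on HeLa cells (Homo sapiens) for cytotoxicity, read by MTT assay, with a stated time of 72 h (a higher number here means a weaker inhibitor of growth, a lower number a stronger inhibitor of growth), compound 1 gives > 30 ug/mL, a limit of the assay rather than a number.
Compound 2 `O=C(/C=C\c1cccc([N+](=O)[O-])c1)N1N=C(c2ccncc2)OC1c1c[nH]c2ccccc12` — in this assay compound 2 gives > 30 ug/mL, again a limit.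
Compound 3 `O=C(/C=C\c1ccc(Cl)cc1)N1N=C(c2ccncc2)OC1c1c[nH]c2ccccc12` — in this assay compound 3 gives > 30 ug/mL, also a limit.

Compound 2 therefore stands at the same place as both of its neighbours: all three values sit at the limit (the limit of > 30 ug/mL in this assay, at which 3 of the 3 values shown sit). The steps that surround it give no readable size: a step that the two limits leave unreadable from compound 1 to compound 2, a step that the two limits leave unreadable from compound 1 to compound 3 and a step that the two limits leave unreadable from compound 2 to compound 3.

The untested compound 4 `O=C(/C=C\c1cccc(Br)c1)N1N=C(c2ccncc2)OC1c1c[nH]c2ccccc12` differs from compound 2 by one change: bromo in place of nitro on an aromatic carbon. The change sits on an aromatic carbon of a six-membered aromatic ring of carbon only, meta to a large group. Since nitro in place of hydrogen and chloro in place of hydrogen both left the value at the limit, the estimated step that the limit leaves unreadable from compound 2 to compound 4 for compound 4 is expected to be none beyond the scatter. Compound 4 is estimated at 40 ug/mL, within 20 ug/mL to 100 ug/mL, most likely reported as a limit again.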

Compound 4, concentration for 50% growth inhibition: > 30 ug/mL
Compound 4: only a limit was reported (the forecaster's own chance of this, stated with the estimate: 85%); the middle value lies beyond the limit too.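

No new step can be read between compound 4 and compound 1, compound 2 or compound 3, because all four stand at the same limit: the limit of > 30 ug/mL in this assay, at which 4 of the 4 values shown sit. The compounds shown leave open where each true value lies, and whether bromo, chloro or nitro changes it at all.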